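The source may hold more compounds than are shown below. What is called first, only, known or untested is meant among the compounds shown, and "the series" means these compounds.

The measured compounds:
compound 1 `COc1cc(N(C)CCN(C)C)c(NC(=O)c2ccncc2OC)cc1Nc1nccc(-c2cn(C)c3ccccc23)n1`, 1010 nM;
compound 2 `COc1cc(N(C)CCN(C)C)c(NC(=O)c2ccncn2)cc1Nc1nccc(-c2cn(C)c3ccccc23)n1`, 1560 nM;
compound 3 `COc1cc(N(C)CCN(C)C)c(NC(=O)c2ccncc2OC)cc1Nc1nccc(-c2cn(CCCO)c3ccccc23)n1`, 1970 nM.

All three were tested in a functional assay on NCI-H1975 cells (Homo sapiens) for antiproliferative activity, read by MTT assay, with a stated time of 72 h; on this read-out higher numbers stand for weaker inhibition and lower numbers for stronger inhibition. Compound 1 and compound 2 differ in one place: pyrimidin-4-yl in place of 3-methoxypyridin-4-yl on a carbonyl carbon. That change gave a 1.5-fold higher number from compound 1 to compound 2 (0.19 log units; within the scatter). Compound 3 carries a different core than compound 1, the difference being (2-hydroxyethyl in place of hydrogen on a saturated chain carbon bound to an aromatic nitrogen), and this gave a 2.0-fold higher number from compound 1 to compound 3 (0.29 log units; within the scatter). Compound 4 `COc1cc(N(C)CCN(C)C)c(NC(=O)c2ccncn2)cc1Nc1nccc(-c2cn(CCCO)c3ccccc23)n1` has not yet been measured. Among the compounds with values here, it differs from compound 3 by pyrimidin-4-yl in place of 3-methoxypyridin-4-yl on a carbonyl carbon, which is the same change as the one from compound 1 to compound 2, made at the same place but on the core of compound 3. Because a 1.5-fold higher number from compound 1 to compound 2 (0.19 log units; within the scatter) stayed within the usual scatter, the expected step for compound 4 is of similar small size: a 1.5-fold higher number from compound 3 to compound 4 (0.17 log units; within the scatter). This rests on one earlier example only, so the expectation is loose. For compound 4 in this assay the estimated value is 2900 nM, with a likely range from 1400 nM to 6000 nM.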

Compound 4, half-maximal inhibitory concentration: 2120 nM
Beside the measured number, compound 4's estimate is 1.4-fold (0.14 log units) above it; measured number inside the range.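

Placing pyrimidin-4-yl in place of 3-methoxypyridin-4-yl on the carbonyl carbon of the core of compound 3 gave a 1.1-fold higher number from compound 3 to compound 4 (0.03 log units; within the scatter) in this assay, and this step matches the earlier one: the same change on two cores in this assay, a 1.5-fold higher number (0.19 log units; within the scatter) from compound 1 to compound 2 and a 1.1-fold higher number (0.03 log units; within the scatter) from compound 3 to compound 4, 1.4-fold (0.16 log units) apart, within the scatter of two such steps. Adding 2-hydroxyethyl in place of hydrogen, now read on the core of compound 2, gave a 1.4-fold higher number from compound 2 to compound 4 (0.13 log units; within the scatter), and this step also matches its earlier counterpart: the same change on two cores in this assay, a 2.0-fold higher number (0.29 log units; within the scatter) from compound 1 to compound 3 and a 1.4-fold higher number (0.13 log units; within the scatter) from compound 2 to compound 4, 1.4-fold (0.16 log units) apart, within the scatter of two such steps. Within the data shown here, each change therefore stayed small on both cores, but with every step within the scatter and only one pair of cores, this does not show that either change has a real effect of its own, nor that a larger effect would carry from one core to another.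

The compounds shown leave open whether any group at these two places could move the number beyond the scatter. A longer chain or an amine in place of the 2-hydroxyethyl group, or a phenyl ring in place of pyrimidin-4-yl on the carbonyl carbon, would help to test this.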